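From naphthalen-2-yl to 4-fluorophenyl on an oxygen

This account rests on a few compounds, and the source may have more. Where it says the series, first, only, none or still open, it means among the compounds named here.

- Compound 1 `O=C(O)CCCCCCC(=O)Nc1ccc(C2=C(c3ccc(O)cc3)C3CC(S(=O)(=O)Oc4ccc(C(F)(F)F)cc4)C2O3)cc1`: 24000 nM
- Compound 2 `O=C(O)CCCCCCC(=O)Nc1ccc(C2=C(c3ccc(O)cc3)C3CC(S(=O)(=O)Oc4ccc5ccccc5c4)C2O3)cc1`: 18900 nM

Going by the values given here, in a functional assay on MCF7 cells (Homo sapiens) for inhibition, read by MTT assay, with a stated time of 72 h (a lower number here means a stronger inhibitor, a higher number a weaker inhibitor), compound 2 gives 18900 nM, a value within the usual scatter of the only other measured compound. Compound 3 `O=C(O)CCCCCCC(=O)Nc1ccc(C2=C(c3ccc(O)cc3)C3CC(S(=O)(=O)Oc4ccc(F)cc4)C2O3)cc1` carries 4-fluorophenyl in place of naphthalen-2-yl on an oxygen. Among the compounds with values here, the one measured change on that oxygen is a 1.3-fold lower number from compound 1 to compound 2 (0.10 log units; within the scatter). Within the data shown here, with only that small step as a guide, no change beyond the scatter is expected in this assay. The expected step is a 1.1-fold higher number from compound 2 to compound 3 (0.05 log units; within the scatter). For compound 3 the estimated value is 21000 nM, with an expected range from 11000 nM to 40000 nM.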

Compound 3, half-maximal inhibitory concentration: 24800 nM
Beside the measured number, compound 3's estimate is 1.2-fold (0.07 log units) below it, within the range that was stated.
By their numbers in this assay, from the lowest: compounds 2, 1 and 3 (each within the scatter of the next).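

In this assay, two fused rings give way to one in a 1.3-fold higher number from compound 2 to compound 3 (0.12 log units; within the scatter) and the step between the two single-ring groups is a 1.0-fold higher number from compound 1 to compound 3 (0.01 log units; within the scatter) on the same oxygen. Losing the second ring and exchanging trifluoromethyl for fluoro therefore both stay within the scatter, so the three aryl groups on this oxygen cannot be told apart here. No measurement is available to explain this lack of separation. Still open, going by these compounds, is whether a different kind of group on this oxygen, such as a pyridine ring or a phenyl ring carrying an amine, would separate from these three.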